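Methoxy for Methyl on a Urea That Shows No Inhibition

The source may hold more compounds than are shown below. What is called first, only, known or untested is meant among the compounds shown, and "the series" means these compounds.

Compound 1 `O=C(Nc1cccc(CNc2ncnc3ccccc23)c1)Nc1ccccc1Cl` and compound 2 `COc1cc2ncnc(NCc3cccc(NC(=O)Nc4ccccc4C)c3)c2cc1OC` were both tested in a functional assay on MGC-803 cells (Homo sapiens) for antiproliferative activity, read by MTT assay; on this read-out higher numbers stand for weaker inhibition and lower numbers for stronger inhibition. Compound 1 gives only a limit there, > 50000 nM. Compound 2 likewise gives only a limit, > 50000 nM. Both results sit at the limit of > 50000 nM in this assay, at which 2 of the 2 values shown sit, so neither compound shows measurable inhibition and nothing in these numbers sets one apart from the other. Compound 3 `COc1ccccc1NC(=O)Nc1cccc(CNc2ncnc3cc(OC)c(OC)cc23)c1` has not yet been measured. It differs from compound 2 in one place: methoxy in place of methyl on an aromatic carbon. Among the measured compounds shown here, no measured pair in this set differs in a single place, so no measured step exists to say how large an effect such a swap has. Since compound 2 sits at a limit > 50000 nM, the step from compound 2 to compound 3 is expected to be none beyond the scatter, a step that the limit leaves unreadable from compound 2 to compound 3. Compound 3 is therefore estimated in this assay at 60000 nM, within a range from 20000 nM to 200000 nM.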

Compound 3, half-maximal inhibitory concentration: 7710 nM
Compound 3: the middle estimate sits 7.8-fold (0.89 log units) above what was measured; the whole stated range lies above it.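

Replacing 2-methylphenyl with 2-methoxyphenyl on the urea gives the only measurable inhibition among the compounds shown, and in this assay this swap produces an at least 6.4-fold lower number from compound 2 to compound 3 (0.81 log units; beyond the scatter) in a pair that differs in that one place alone. The position on this aromatic ring therefore responds to substitution, and one change of methyl to methoxy, adding one oxygen and one hydrogen-bond acceptor by count, is enough to move a compound out of the no-inhibition range. Going by these compounds, the full size of the step stays unknown because compound 2 gives only a limit of the assay: the limit of > 50000 nM in this assay, at which 2 of the 3 values shown sit.

On these data alone, whether methoxy is unusual here remains open, since an ethoxy group, a hydroxyl or an amine at the same place would be needed to test it. It is also unclear whether the same swap would help on a core without the two methoxy groups, as compound 1 differs from compound 3 in more than one place.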